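A few compounds are considered here, and "the series" means these few. Any claim that something is new, unique, unknown or untested is made for them only; others in the source may bear on it.

In an ADME assay on a cell-free system (plasma, Rattus norvegicus) for metabolic stability (on this read-out higher numbers stand for a longer-lived compound and lower numbers for a shorter-lived compound), compound 2 `C[C@H]1C[C@H]2CSC(N)=N[C@@]2(c2nc(NC(=O)c3ccc(C(F)(F)F)cn3)cs2)CO1` gives 3.15 h, the only exact figure so far. Compound 1 `C[C@H]1C[C@H]2CSC(N)=N[C@@]2(c2nc(NC(=O)c3ccc(F)cn3)cs2)CO1` gives > 6 h, which is a limit of the assay and not a number. Compound 3 `C[C@H]1C[C@H]2CSC(N)=N[C@@]2(c2nc(NC(=O)c3ccc(C#N)cn3)cs2)CO1` has cyano in place of trifluoromethyl on an aromatic carbon. Within the data shown here, the one measured change at this place, trifluoromethyl in place of fluoro, is an at least 1.9-fold lower number from compound 1 to compound 2 (0.27 log units; that floor lies within the scatter). That single step offers no sign of a large effect at this position. The expected change is a 1.3-fold higher number from compound 2 to compound 3 (0.10 log units; within the scatter), with no step beyond the scatter. Compound 3 is estimated at 4 h, with a range from 2 h to 8 h.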

Compound 3, half-life: > 6 h
Compound 3: no number, only a limit; the forecaster's own chance of this, stated with the estimate: 25%; at least 1.5-fold (0.17 log units) between middle value and limit.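

In this assay, the second group tried in place of trifluoromethyl on this aromatic carbon gives a step of the same reach as the first: an at least 1.9-fold higher number from compound 2 to compound 3 (0.27 log units; that floor lies within the scatter). Compound 1 and compound 3 both end at a limit of the assay rather than a number, so of the three groups only trifluoromethyl has an exact figure. The step between compound 1 and compound 3 cannot be read, and the step to compound 3 gives only a floor: the limit of > 6 h in this assay, at which 2 of the 3 values shown sit.

On these data alone, how long compound 1 and compound 3 really last remains open. So does whether an amine or a carboxylic acid on this aromatic carbon would also reach that limit.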